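Amide nitrogen substituent swap on the benzimidazole-type series

The source may hold more compounds than are shown below. What is called first, only, known or untested is meant among the compounds shown, and "the series" means these compounds.

Measured so far in an assay on isolated protein for inhibition of NEDD8-activating enzyme E1 regulatory subunit (Homo sapiens), read by Western blot, with stated times of 10 min and 30 min, tested at 25 uM; on this read-out higher numbers stand for more inhibition at the one concentration tested (going by the name of the read-out) and lower numbers for less inhibition:
- compound 1 `CCOC(=O)CNC(=O)c1cccc2nc(OCC)n(Cc3ccc(-c4ccccc4-c4nnn[nH]4)cc3)c12`: 46.5%
- compound 2 `CCOc1nc2cccc(C(=O)Nc3ccc(S(N)(=O)=O)cc3)c2n1Cc1ccc(-c2ccccc2-c2nnn[nH]2)cc1`: 60.9%

Compound 2 stands highest of the two numbers, and its nearest neighbour, compound 1, sits a step lower that is beyond the scatter: a number 14.4 percentage points higher from compound 1 to compound 2 (beyond the scatter). Among the compounds with values here, that step exchanges the (ethoxycarbonyl)methyl group on the amide-type nitrogen for 4-sulfamoylphenyl, and it is the only measured step in this set.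

Compound 3 `CCOc1nc2cccc(C(=O)NOCc3ccccc3)c2n1Cc1ccc(-c2ccccc2-c2nnn[nH]2)cc1` is not yet measured. It differs from compound 2 by benzyloxy in place of 4-sulfamoylphenyl on an amide-type nitrogen. Within the data shown here, the one measured step bears on it only indirectly: it shows that the group on this amide-type nitrogen can move the read-out by a modest amount beyond the scatter, and that 4-sulfamoylphenyl gave the higher number. Among the measured compounds shown here, no measured compound carries benzyloxy or any oxygen-linked group at this position, so the direction of the change is not fixed by the data.

Removing 4-sulfamoylphenyl is expected to cost part of the gain seen in compound 2, giving an estimated step of a number 15.9 percentage points lower from compound 2 to compound 3 (beyond the scatter). Compound 3 is therefore estimated at 45%, with a range from 25% to 65%.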

Compound 3, a percentage reported as inhibition, at one concentration (the size of the read-out at that concentration, not a potency): 39.8%
Compound 3: middle estimate off by 5.2 percentage points, on the high side, within the range that was stated.
By their numbers in this assay, from the lowest: compounds 3 and 1 (each within the scatter of the next); then compound 2.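

In this assay, the change of 4-sulfamoylphenyl to benzyloxy on the amide-type nitrogen gives a number 21.1 percentage points lower from compound 2 to compound 3 (beyond the scatter), so the higher number of compound 2 does not carry over to this oxygen-linked group, even though both groups hold one six-membered aromatic ring of carbon only. Set against the (ethoxycarbonyl)methyl group, benzyloxy gives a number 6.7 percentage points lower from compound 1 to compound 3 (within the scatter), so two groups with quite different atoms cannot be told apart on this read-out, and among the three compounds only compound 2 stands clear of the others, by steps beyond the scatter. Nothing at hand gives a reason for this separation of 4-sulfamoylphenyl from the other two groups.

The compounds shown leave open whether the higher number of compound 2 goes with the sulfamoyl part of its group or with the phenyl ring carried on the nitrogen, a question that a plain phenyl or a 4-carboxyphenyl group at this place would address. On these data alone, it also remains open whether a free carboxylic acid in place of the ethyl ester of compound 1 would shift the number on this read-out.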